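Benzylamide series: methoxy to fluoro on the benzyl ring

The source may hold more compounds than are shown below. What is called first, only, known or untested is meant among the compounds shown, and "the series" means these compounds.

Measured so far in an assay on microsomes from liver for inhibition of 3-hydroxy-3-methylglutaryl-coenzyme A reductase (Rattus norvegicus), read by scintillation counting, with stated times of 0.5 h and 0.75 h; a higher number here means a weaker inhibitor, a lower number a stronger inhibitor:
- compound 1 `COc1ccc(CNC(=O)c2nc(-c3ccc(F)cc3)n(CC[C@@H](O)C[C@@H](O)CC(=O)O)c2C2CC2)cc1F` gives 3.7 nM
- compound 2 `CC(C)c1c(C(=O)NCc2ccccc2)nc(-c2ccc(F)cc2)n1CC[C@@H](O)C[C@@H](O)CC(=O)O` gives 7.9 nM
- compound 3 `CCc1c(C(=O)NCc2ccccc2)nc(-c2ccc(F)cc2)n1CC[C@@H](O)C[C@@H](O)CC(=O)O` gives 123 nM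

Compound 1 holds the lowest number of the three; compound 2 stands nearest, compound 3 furthest, both beyond the scatter, so compound 1 is the strongest inhibitor measured here.

Compound 4 `O=C(O)C[C@H](O)C[C@H](O)CCn1c(-c2ccc(F)cc2)nc(C(=O)NCc2ccc(F)c(F)c2)c1C1CC1` is not yet measured. It differs from compound 1 in one place: fluoro in place of methoxy on an aromatic carbon.

Going by the values given here, no measured step touches this position. Among the compounds with values here, the only step recorded, a 16-fold higher number from compound 2 to compound 3 (1.19 log units; beyond the scatter), concerns the group on the shared core, not the benzyl ring, and so says nothing about an exchange there. Without a comparator, no step beyond the scatter is expected from compound 1 to compound 4 in this assay, and the estimated change is a 1.2-fold higher number from compound 1 to compound 4 (0.09 log units; within the scatter). Compound 4 is therefore expected to give about 4.5 nM, in a range from 1.8 nM to 12 nM.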

Compound 4, half-maximal inhibitory concentration: 1.2 nM
For compound 4 the middle estimate is 3.8-fold (0.57 log units) above the measured one, and the stated range ends above it.
By their numbers in this assay, from the lowest: compound 4; then compound 1; then compound 2; then compound 3.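

In this assay this position on the benzyl ring responds to substitution: fluoro in place of methoxy, para to a large group and ortho to a fluoro group, gives a 3.1-fold lower number from compound 1 to compound 4 (0.49 log units; beyond the scatter). Going by these compounds alone, the methoxy group is therefore not required for strong inhibition here, and one heavy atom in its place gives the lowest number so far. Nothing at hand gives a reason for this step.

Still open, as far as these compounds go, is how chloro, hydroxyl or an amine would compare at this position. Also open, from the compounds shown here alone, is whether the same exchange gives a similar step on a core carrying isopropyl instead of cyclopropyl.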